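Flipping One Stereocentre on the Methylcyclopropyl Amide

The source may hold more compounds than are shown below. What is called first, only, known or untested is meant among the compounds shown, and "the series" means these compounds.

Compound 1, `O=C(C1CCC1)N1CC2CC(C1)N2`: 2900 nM
Compound 2, `O=C([C@H]1C[C@@H]1F)N1CC2CC(C1)N2`: 850 nM
Compound 3, `C[C@@H]1C[C@@H]1C(=O)N1CC2CC(C1)N2`: 2100 nM

All three share one core and differ only in the group on the carbonyl carbon, each tested in an assay on SH-EP1 cells for agonist activity at Neuronal acetylcholine receptor; alpha4/beta2 (Homo sapiens), read by FLIPR and calcium flux; on this read-out lower numbers stand for an effect already at smaller amounts and higher numbers for an effect only at larger amounts of compound. Compound 3 stands second highest of the three numbers: the step of a 1.4-fold lower number from compound 1 to compound 3 (0.14 log units; within the scatter) lies within the scatter, whereas the step of a 2.5-fold higher number from compound 2 to compound 3 (0.39 log units; beyond the scatter) is beyond it. Compound 4, `C[C@@H]1C[C@H]1C(=O)N1CC2CC(C1)N2`, differs from compound 3 in that (the two compounds have the same atoms and bonds; at least one stereo element is drawn with a configuration in one of them and without one in the other: 1 of 4 stereo elements differ; a stereocentre at a saturated ring carbon is drawn S in compound 3 and R in compound 4). Among the measured compounds shown here, no measured step alters a stereocentre alone, so none bears directly on this change; the ring swaps behind a 1.4-fold lower number from compound 1 to compound 3 (0.14 log units; within the scatter) and a 2.5-fold higher number from compound 2 to compound 3 (0.39 log units; beyond the scatter) were at most modest. The expected step is therefore a 1.2-fold higher number from compound 3 to compound 4 (0.08 log units; within the scatter), not beyond the scatter. Compound 4 is estimated at 2500 nM, with a range from 800 nM to 8000 nM in this assay.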

Compound 4, half-maximal effective concentration: 190 nM
Estimate against measurement, compound 4: 13-fold (1.12 log units) above; the whole stated range lies above it.
By their numbers in this assay, from the lowest: compound 4; then compound 2; then compounds 3 and 1 (each within the scatter of the next).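

In this assay the drawn configuration of one saturated ring carbon turns out to matter greatly, with an 11-fold lower number from compound 3 to compound 4 (1.04 log units; beyond the scatter) even though the atoms and bonds stay the same. The group on the carbonyl carbon is thus not judged by its ring alone: with this configuration, 2-methylcyclopropyl gives a 15-fold lower number from compound 1 to compound 4 (1.18 log units; beyond the scatter) against cyclobutyl and a 4.5-fold lower number from compound 2 to compound 4 (0.65 log units; beyond the scatter) against 2-fluorocyclopropyl. On these data alone, whether an ethyl group or an amine in place of the methyl would respond to this configuration in the same way remains open. Reading the step as a clean swap of one configuration for another also needs care: the fact that one of compounds 3 and 4 is drawn with a defined configuration and the other without, at the place where they differ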